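Toward a tert-butylacetylene analogue in the cytotoxicity series

The source may hold more compounds than are shown below. What is called first, only, known or untested is meant among the compounds shown, and "the series" means these compounds.

Compound 1 `O=c1[nH]c(=O)n([C@H]2C[C@H](O)[C@@H](CO)O2)cc1C#Cc1ccccc1`: > 200000 nM in an ADME assay on L1210/0 cells (Mus musculus) for cytotoxicity, with a stated time of 48 h; on this read-out lower numbers stand for stronger inhibition and higher numbers for weaker inhibition
Compound 2 `CCCc1cn([C@H]2C[C@H](O)[C@@H](CO)O2)c(=O)[nH]c1=O`: > 200000 nM in this assay

Both values shown are limits of this assay rather than numbers. For compound 1 the reading of > 200000 nM is such a limit. For compound 2 the reading of > 200000 nM is likewise a limit. The step that the two limits leave unreadable from compound 1 to compound 2 therefore cannot be read in size or direction, since both of its ends sit at the limit of > 200000 nM in this assay, at which 2 of the 2 values shown sit.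

Compound 2 thus stands at the limit of this assay, as does the one other compound shown, and no ranking between the two can be drawn.

The next compound, compound 3 `CC(C)(C)C#Cc1cn([C@H]2C[C@H](O)[C@@H](CO)O2)c(=O)[nH]c1=O`, differs from compound 2 by 3,3-dimethylbut-1-yn-1-yl in place of propyl on an aromatic carbon. Within the data shown here, the only measured step, from compound 1 to compound 2, bears on this change in that it also exchanges a chain for an alkynyl group at the same aromatic carbon, but it is unreadable, so no size of step can be inferred from it. With both neighbours at the limit, the expectation for compound 3 in this assay is that it also reaches the limit, and the step that the limit leaves unreadable from compound 2 to compound 3 is estimated to stay within the scatter. Compound 3 is accordingly estimated at 300000 nM, with a range from 100000 nM to 1000000 nM.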

Compound 3, half-maximal inhibitory concentration: > 200000 nM
Compound 3: a limit, no number (the forecaster's own chance of this, stated with the estimate: 85%); the middle value is on the limit's open side.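

Among these compounds, compound 3 also reads as a limit in this assay, so no step among compound 1, compound 2 and compound 3 can be read in size or direction: the limit of > 200000 nM in this assay, at which 3 of the 3 values shown sit. The compounds shown leave open how these three rank and whether any group on this aromatic carbon gives a measurable value in this assay.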